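Methyl in place of hydrogen: compound 2 to compound 4

The source may hold more compounds than are shown below. What is called first, only, known or untested is meant among the compounds shown, and "the series" means these compounds.

Compound 2 `CN(C)CCNc1nc(-c2ccc(NC(=O)Nc3ccccc3)cc2)nc2ccsc12` gives 640 nM in a functional assay on NCI-H460 cells (Homo sapiens) for cytotoxicity, read by MTT assay, with a stated time of 72 h; a lower number here means a stronger inhibitor, a higher number a weaker inhibitor. Among the three measured compounds it stands highest on the numbers: compound 1 `CN(C)CCCNc1nc(-c2ccc(NC(=O)Nc3ccccc3Cl)cc2)nc2ccsc12` gives 430 nM, within the scatter of compound 2, while compound 3 `CN(C)CCNc1nc(-c2ccc(NC(=O)Nc3ccc(Cl)cc3)cc2)nc2c(Cl)c(Cl)sc12` gives 300 nM, a gap beyond the scatter. Compound 4 `Cc1ccc(NC(=O)Nc2ccc(-c3nc(NCCN(C)C)c4sccc4n3)cc2)cc1` differs from compound 2 by methyl in place of hydrogen on an aromatic carbon, para to a large group. For the measured compounds named here, no measured pair isolates this change, so no step can be drawn from the data. The change is one heavy atom, and the expected step in this assay, a 1.2-fold lower number from compound 2 to compound 4 (0.07 log units; within the scatter), is none beyond the scatter in either direction. Compound 4 is accordingly estimated at 550 nM, with a range from 220 nM to 1400 nM.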

Compound 4, half-maximal inhibitory concentration: 1880 nM
The estimate for compound 4 lay 3.4-fold (0.53 log units) below the measured number; the measured number lies above the stated range.
By their numbers in this assay, from the lowest: compounds 3, 1 and 2 (each within the scatter of the next, the first and the last beyond it); then compound 4.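

In this assay, phenyl to 4-methylphenyl is not a silent change: a 2.9-fold higher number from compound 2 to compound 4 (0.47 log units; beyond the scatter) is the only single-place step shown in the series, and it runs towards a weaker inhibitor. One added carbon at this position is therefore enough to move the number beyond the scatter. Nothing at hand bears on the reason for this step. As far as these compounds go, whether a methoxy group, an amine or a carboxylic acid at the same place on this ring gives a step of similar size or direction remains open.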